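From compound 1 to compound 4: adding 4-cyanophenyl

The source may report more compounds than this note shows. Statements on the series, on what has been measured and on what is new or still open speak of the compounds shown alone.

Of the compounds shown here, three sharing one core have been measured in a functional assay on HL-60 cells (Homo sapiens) for cytotoxicity, read by CCK-8 assay, with a stated time of 24 h; a higher number here means a weaker inhibitor, a lower number a stronger inhibitor. Compound 1 `C=CC(=O)N1C(=O)CCSc2ccccc21` gives 44800 nM, the lowest number of the three. Compound 2 `C=CC(=O)N1C(=O)CC(c2ccccc2C(F)(F)F)Sc2ccccc21` gives 96400 nM, and compound 3 `C=CC(=O)N1C(=O)CC(c2ccc(C(=O)OC)cc2)Sc2ccccc21` gives 102000 nM. These two values lie within the scatter of each other, and both stand higher than that of compound 1 by more than the scatter.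

Compound 4 `C=CC(=O)N1C(=O)CC(c2ccc(C#N)cc2)Sc2ccccc21` has not yet been measured. Its difference from compound 1 is 4-cyanophenyl in place of hydrogen on a saturated ring carbon. Going by the values given here, no measured pair differs in one place only, so the expectation rests on the values alone. Compound 2, at 96400 nM, and compound 3, at 102000 nM, also carry a substituted phenyl group on the shared core. A step of similar size toward weaker inhibition in this assay is therefore expected, estimated as a 2.1-fold higher number from compound 1 to compound 4 (0.33 log units; beyond the scatter). The estimated value for compound 4 is 95000 nM, with an expected range of 52000 nM to 170000 nM.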

Compound 4, half-maximal inhibitory concentration: 115000 nM
Beside the measured number, compound 4's estimate is 1.2-fold (0.08 log units) below it, and the stated range covers the measured number.
By their numbers in this assay, from the lowest: compound 1; then compounds 2, 3 and 4 (each within the scatter of the next).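

In this assay, a change in one place can now be read at this position: 4-cyanophenyl in place of hydrogen on a saturated ring carbon, next to the ring sulfur, gives a 2.6-fold higher number from compound 1 to compound 4 (0.41 log units; beyond the scatter), a modest step toward weaker inhibition. Going by these compounds alone, the substituent on the aromatic ring makes no readable difference in the one pair that tests it, as cyano in place of methoxycarbonyl gives a 1.1-fold higher number from compound 3 to compound 4 (0.05 log units; within the scatter), a step within the scatter. Nothing measured here speaks to why the substituted phenyl group raises the number.

As far as these compounds go, only hydrogen and substituted phenyl groups appear on this carbon, so it remains open whether a methyl group or an unsubstituted phenyl would give a similar step from compound 1. From the compounds shown here alone, it is also open whether an amine or a carboxylic acid in place of the cyano group would separate from compound 4 in this assay.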